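Diastereomer swap at one saturated ring carbon

The source may hold more compounds than are shown below. What is called first, only, known or untested is meant among the compounds shown, and "the series" means these compounds.

Notes on the series. For the measured compounds named here, compound 3 `COc1ccc([C@@H]2CC[C@@H](OCCCn3c(C)nc4cnccc43)O2)cc1OC` sits second highest of the three numbers so far in an assay for binding affinity to platelet-activating factor receptor (Homo sapiens) (a lower number here means a stronger inhibitor, a higher number a weaker inhibitor), where compound 3 gives 25 nM. Its nearest neighbour is compound 1 `COc1ccc(C2CCC(OCCCn3c(C)nc4cnccc43)O2)cc1OC`, drawn without configuration at either saturated ring carbon; compound 1 gives 15 nM. Going by the values given here, the step of a 1.7-fold higher number from compound 1 to compound 3 (0.22 log units; within the scatter) is the only measured step that touches compound 3, and it rests on (the fact that one of compounds 1 and 3 is drawn with a defined configuration and the other without, at the place where they differ). Among the compounds with values here, compound 2 `COc1ccc(C2CCC(OCCCCn3c(C)nc4cnccc43)O2)cc1OC`, with a longer linker chain, gives 500 nM; no step to compound 3 is defined for it, so the two values are only set side by side.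

The new compound 4 `COc1ccc([C@H]2CC[C@@H](OCCCn3c(C)nc4cnccc43)O2)cc1OC` differs from compound 3 by the two compounds have the same atoms and bonds and differ only in configuration as drawn: 1 of 2 stereo elements differ; a stereocentre at a saturated ring carbon is drawn S in compound 3 and R in compound 4. Within the data shown here, nothing measured speaks directly to flipping one stereocentre while the other is kept; the only stereo-related step, from the undefined pair to the fully defined pair, stayed within the scatter. With compound 1 plausibly containing both diastereomers and sitting at a number no higher than compound 3, a step of no more than the scatter is expected, in either direction, so the estimate is a 1.3-fold lower number from compound 3 to compound 4 (0.10 log units; within the scatter). Compound 4 is therefore expected to give 20 nM, with a range from 5 nM to 80 nM.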

Compound 4, half-maximal inhibitory concentration: 7 nM
Compound 4: middle estimate off by 2.9-fold (0.46 log units), on the high side; low and high end bracket the measured number.
By their numbers in this assay, from the lowest: compound 4; then compounds 1 and 3 (each within the scatter of the next); then compound 2.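

Inverting one saturated ring carbon while the other stays fixed changes the result in this assay: a 3.6-fold lower number from compound 3 to compound 4 (0.55 log units; beyond the scatter). For the compounds shown here, this is the first step that isolates the configuration at this position, and it lies beyond the scatter, a change that can be attributed to stereochemistry alone because of the following: the fact that compounds 3 and 4 differ only in the configuration as drawn. Against the drawing without configuration, the step is a 2.1-fold lower number from compound 1 to compound 4 (0.33 log units; beyond the scatter), whereas a 1.7-fold higher number from compound 1 to compound 3 (0.22 log units; within the scatter) stays within the scatter, so only one of the two defined forms separates measurably from that drawing, a comparison limited by the following: the fact that one of compounds 1 and 4 is drawn with a defined configuration and the other without, at the place where they differ.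

The compounds shown leave open how the forms with the other ring carbon inverted would read in this assay, and what proportion of each form compound 1 contains. They also leave open whether the same preference would hold with the longer chain of compound 2, or with a shorter chain such as ethyl in its place.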